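Swapping the Aryl Ring on the Amide of Compound 3

This account rests on a few compounds, and the source may have more. Where it says the series, first, only, none or still open, it means among the compounds named here.

Compound 3 `COc1ccc(C(=O)NCCCOc2cc(=O)n(CCCO)c3c2CC(C/C=C(\C)CCC=C(C)C)C(C)(C)C3)cc1` gives 45.7% in a functional assay on PANC-1 cells (Homo sapiens) for inhibition, read by MTT assay, with a stated time of 24 h, tested at 10 uM (a lower number here means less inhibition, a higher number more inhibition at the concentration tested (going by the name of the read-out)), the second highest of three numbers. Compound 1 `CCOc1cc(=O)n(CCCO)c2c1CC(C/C=C(\C)CCC=C(C)C)C(C)(C)C2` gives 67.8%, so the full side chain costs activity: a number 22.1 percentage points lower from compound 1 to compound 3 (beyond the scatter). Compound 2 `CC(C)=CCC/C(C)=C/CC1Cc2c(OCCCNS(=O)(=O)c3ccc([N+](=O)[O-])cc3)cc(=O)n(CCCO)c2CC1(C)C` gives 7.4%, and the change of sulfonyl to carbonyl helps greatly: a number 38.3 percentage points higher from compound 2 to compound 3 (beyond the scatter). As far as these compounds go, compound 4 `CC(C)=CCC/C(C)=C/CC1Cc2c(OCCCNC(=O)c3cccs3)cc(=O)n(CCCO)c2CC1(C)C` is untested; it differs from compound 3 by thiophen-2-yl in place of 4-methoxyphenyl on a carbonyl carbon. Neither measured step touches the ring on the carbonyl carbon, so they only show that this side group matters. An exchange of one aromatic ring for another there is expected to move the number little, estimated as a number 3.7 percentage points lower from compound 3 to compound 4 (within the scatter). Compound 4 is therefore expected to give 42%, between 25% and 58%.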

Compound 4, a percentage reported as inhibition, at one concentration (the size of the read-out at that concentration, not a potency): 72.8%
The estimate for compound 4 lay 30.8 percentage points below the measured number; measured number outside the range, above it.
By their numbers in this assay, from the lowest: compound 2; then compound 3; then compounds 1 and 4 (each within the scatter of the next).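

The ring on the carbonyl carbon strongly affects the read-out in this assay: thiophen-2-yl in place of 4-methoxyphenyl gives a number 27.1 percentage points higher from compound 3 to compound 4 (beyond the scatter). The loss seen with the earlier amide side chain therefore depends on its ring, since the thiophene amide shows a number 5 percentage points higher from compound 1 to compound 4 (within the scatter), and exchanging the sulfonamide side group for this amide gives a number 65.4 percentage points higher from compound 2 to compound 4 (beyond the scatter). No available evidence explains the gain. As far as these compounds go, whether it follows the sulfur, the five-membered ring or the missing methoxy group stays open; phenyl or furan-2-yl on that carbonyl carbon would help separate these.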